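The source may report more compounds than this note shows. Statements on the series, on what has been measured and on what is new or still open speak of the compounds shown alone.

Measured so far:
compound 1 `CC1CCN(c2c(S(=O)(=O)c3ccc(F)c(Cl)c3)cnc3cc(Cl)ccc23)CC1` — 94%
compound 2 `CC1CCN(c2c(S(=O)(=O)c3ccc(F)c(Cl)c3)cnc3cc(F)ccc23)CC1` — 94%

In an assay on isolated protein for displacement of a labelled ligand from metabotropic glutamate receptor 5 (Homo sapiens), with a stated time of 60 min, tested at 1 uM (on this read-out higher numbers stand for more inhibition at the one concentration tested (going by the name of the read-out) and lower numbers for less inhibition), compound 1 gives 94% and stands level with compound 2 at the digits shown. Compound 3 `CC1CCN(c2c(S(=O)(=O)c3ccccc3)cnc3cc(Cl)ccc23)CC1` differs from compound 1 by phenyl in place of 3-chloro-4-fluorophenyl on a sulfonyl sulfur. Among the measured compounds shown here, the one measured step, no change at the digits printed from compound 1 to compound 2 (within the scatter), concerns a different place and a swap of one halogen for another, so it only shows that the number in this assay stays level across that small change. Stripping both halogens from the ring on the sulfonyl sulfur is a larger change, and a modest loss is expected: a number 19 percentage points lower from compound 1 to compound 3 (beyond the scatter). Compound 3 is estimated at 75%, within 40% to 95%.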

Compound 3, a percentage reported as inhibition, at one concentration (the size of the read-out at that concentration, not a potency): 93%
The estimate for compound 3 lay 18 percentage points below the measured number; the measured number falls inside the stated range.
By their numbers in this assay, from the lowest: compounds 3, 1 and 2 (each within the scatter of the next).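

In this assay phenyl in place of 3-chloro-4-fluorophenyl on the sulfonyl sulfur gives a number 1 percentage points lower from compound 1 to compound 3 (within the scatter) and so shows that neither halogen on that ring is needed for the inhibition seen at this one concentration. The earlier step changed a halogen elsewhere on the shared core and said nothing about this place. No measurement shown explains this result.

From the compounds shown here alone, whether an amine or a carboxylic acid on this phenyl ring would keep the number level remains open. A reading at one concentration also leaves open whether compound 1 and compound 3 differ in potency.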